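Pyridinylmethylamino variant of the piperidine series: expected potency

The source may hold more compounds than are shown below. What is called first, only, known or untested is meant among the compounds shown, and "the series" means these compounds.

Compound 2 `CN(Cc1ccsc1)C1CCN(CCCc2c[nH]c3ccc(-n4cnnc4)cc23)CC1` carries the shared core with a methyl((thiophen-3-yl)methyl)amino group on a saturated ring carbon. In an assay on CHO cells for displacement of a labelled ligand from 5-hydroxytryptamine receptor 1D (Homo sapiens) (a higher number here means a weaker inhibitor, a lower number a stronger inhibitor), compound 2 gives 1.5 nM. Within the data shown here, compound 1 `c1ccc(CNCC2CCN(CCCc3c[nH]c4ccc(-n5cnnc5)cc34)CC2)cc1` is the only other member measured; in this assay compound 1 gives 1.6 nM, and the step of a 1.1-fold lower number from compound 1 to compound 2 (0.03 log units; within the scatter) is within the scatter, so the two numbers do not separate.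

Compound 3 `c1cncc(CNC2CCN(CCCc3c[nH]c4ccc(-n5cnnc5)cc34)CC2)c1` differs from compound 2 by ((pyridin-3-yl)methyl)amino in place of methyl((thiophen-3-yl)methyl)amino on a saturated ring carbon. Among the measured compounds shown here, the single measured step, from compound 1 to compound 2, exchanged a different pair of groups at the same place and left this assay unchanged, which is the only guidance available. No step beyond the scatter is therefore expected in this assay. The expected step is a 1.3-fold higher number from compound 2 to compound 3 (0.12 log units; within the scatter). Compound 3 is estimated at 2 nM, with a range from 0.7 nM to 6 nM.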

Compound 3, half-maximal inhibitory concentration: 35 nM
The estimate for compound 3 lay 18-fold (1.24 log units) below the measured number, and the stated range ends below it.
By their numbers in this assay, from the lowest: compounds 2 and 1 (each within the scatter of the next); then compound 3.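

The position on the saturated ring carbon is not indifferent to its substituent in this assay: the match between compounds 1 and 2 does not extend to ((pyridin-3-yl)methyl)amino, which gives a 23-fold higher number from compound 2 to compound 3 (1.37 log units; beyond the scatter) and a 22-fold higher number from compound 1 to compound 3 (1.34 log units; beyond the scatter). The amine hydrogen alone does not go with a high number, since compound 1 also carries one and gives 1.6 nM. No measurement shown here gives a reason for the rise.

The step from compound 2 to compound 3 changes the aromatic ring and removes the methyl on the amine together, so the two changes cannot be separated. Methyl((pyridin-3-yl)methyl)amino or benzylamino on the same ring carbon would tell them apart, and the pyridin-2-yl and pyridin-4-yl isomers would show whether the place of the ring nitrogen matters.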